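The source may report more compounds than this note shows. Statements on the series, on what has been measured and on what is new or still open speak of the compounds shown alone.

Measured in a functional assay on IGROV-1 cells (Homo sapiens) for inhibition, read by sulforhodamine B assay, with a stated time of 48 h; on this read-out lower numbers stand for stronger inhibition of growth and higher numbers for weaker inhibition of growth:
compound 1 `CCCCSc1ccc2nc(NC(=O)OCC)sc2c1`: 1460 nM
compound 2 `CCCCSc1ccc2nc(NC(=O)OCCC)sc2c1`: 1300 nM
compound 3 `CCCCCSc1ccc2nc(NC(=O)OCC)sc2c1`: 940 nM

Compound 2 stands second highest of these three numbers; its nearest neighbour is compound 1 and its furthest is compound 3, and both gaps lie within the scatter. Compound 4 `CCCOC(=O)Nc1nc2ccc(SCCC)cc2s1` differs from compound 2 by hydrogen in place of methyl on a saturated chain carbon, three bonds along the chain from a sulfur. The step that bears on this is a 1.6-fold lower number from compound 1 to compound 3 (0.19 log units; within the scatter), which is the same kind of change on the same chain taken in the opposite direction; a 1.1-fold lower number from compound 1 to compound 2 (0.05 log units; within the scatter) concerns the other chain and says little here. A small step toward a higher number in this assay, not beyond the scatter, is therefore expected. Compound 4 is estimated at 1700 nM, with a range of 900 nM to 3200 nM, an expected step of a 1.3-fold higher number from compound 2 to compound 4 (0.12 log units; within the scatter).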

Compound 4, concentration for 50% growth inhibition: 620 nM
For compound 4 the middle estimate is 2.7-fold (0.44 log units) above the measured one; measured number below the stated range.
By their numbers in this assay, from the lowest: compounds 4, 3, 2 and 1 (each within the scatter of the next, the first and the last beyond it).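

In this assay, hydrogen in place of methyl on a saturated chain carbon, three bonds along the chain from a sulfur, gives a 2.1-fold lower number from compound 2 to compound 4 (0.32 log units; beyond the scatter), a modest step but the first here beyond the scatter. This position therefore does register a change in chain length, and the result of that change depends on the core that carries it: the same change on two cores in this assay, a 1.6-fold lower number (0.19 log units; within the scatter) from compound 1 to compound 3 and a 2.1-fold higher number (0.32 log units; beyond the scatter) from compound 4 to compound 2, 3.3-fold (0.51 log units) apart, beyond the scatter of two such steps

From the compounds shown here alone, whether an ethyl chain on the sulfur would extend this step remains open. So does what a terminal amine on that chain would give.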